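Replacing 2,4-difluorobenzyl with 2,3-dihydroxybenzyl

The compounds below may be only part of what the source reports. "The series", "measured", "known", "first", "only" and "open" are said of these compounds alone.

Within the data shown here, in a functional assay on K562 cells (Homo sapiens) for antiproliferative activity, with a stated time of 72 h (on this read-out lower numbers stand for stronger inhibition and higher numbers for weaker inhibition), compound 3 (`OC[C@H]1O[C@@H](n2cnc3c(NCc4ccc(F)cc4F)ncnc32)[C@H](O)[C@@H]1O`) gives 9600 nM and holds the lower of the two actual numbers so far. Compound 1 (`OC[C@H]1O[C@@H](n2cnc3c(NCc4ccc(Br)cc4)ncnc32)[C@H](O)[C@@H]1O`) gives 68200 nM on the same read-out. Compound 2 (`COc1cccc(CNc2ncnc3c2ncn3[C@@H]2O[C@H](CO)[C@@H](O)[C@H]2O)c1OC`) reads > 166000 nM as a limit of the assay and not a number.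

The next analogue is compound 4 (`OC[C@H]1O[C@@H](n2cnc3c(NCc4cccc(O)c4O)ncnc32)[C@H](O)[C@@H]1O`). Its difference is 2,3-dihydroxyphenyl in place of 2,4-difluorophenyl on a saturated chain carbon bound to a nitrogen on an aromatic ring and places 2,3-dihydroxyphenyl in place of 2,4-difluorophenyl on a saturated chain carbon bound to a nitrogen on an aromatic ring.

Among the measured compounds shown here, three measured steps bear on this change. Moving away from the 4-bromophenyl group gave a 7.1-fold lower number from compound 1 to compound 3 (0.85 log units; beyond the scatter) in one direction and an at least 2.4-fold higher number from compound 1 to compound 2 (0.38 log units; beyond the scatter) in the other. The 2,3-dimethoxyphenyl group is the closest relative of the entering group, and the step from it was large, at an at least 17-fold lower number from compound 2 to compound 3 (1.23 log units; beyond the scatter) in total.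

A clear loss is therefore expected, estimated as a 4.2-fold higher number from compound 3 to compound 4 (0.62 log units; beyond the scatter) in this assay and so beyond the scatter. Compound 4 is estimated at 40000 nM within an expected range of 7000 nM to 170000 nM on this read-out.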

Compound 4, half-maximal inhibitory concentration: 25800 nM
Beside the measured number, compound 4's estimate is 1.6-fold (0.19 log units) above it, within the range that was stated.
By their numbers in this assay, from the lowest: compound 3; then compound 4; then compound 1. At a limit, above all of these: compound 2.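

In this assay, the 2,3-dihydroxyphenyl group falls between the two halogenated groups: exchanging 2,4-difluorophenyl for it gives a 2.7-fold higher number from compound 3 to compound 4 (0.43 log units; beyond the scatter), while exchanging 4-bromophenyl for it gives a 2.6-fold lower number from compound 1 to compound 4 (0.42 log units; beyond the scatter). The earlier compounds shown here offered only 2,3-dimethoxyphenyl as a guide to this change, and replacing that group with 2,3-dihydroxyphenyl gives an at least 6.4-fold lower number from compound 2 to compound 4 (0.80 log units; beyond the scatter), so two groups with the same numbering in their names read very differently at this position. That step is only a bound, and compound 2 is read by a limit of the assay and not a number: the limit of > 166000 nM in this assay, at which 1 of the 4 values shown sits.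

The compounds shown leave open whether both hydroxyl groups are needed, which a phenyl group carrying a single hydroxyl could test. They also leave open whether an aminophenyl group at this position would read like the 2,3-dihydroxyphenyl group.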